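This account rests on a few compounds, and the source may have more. Where it says the series, first, only, none or still open, it means among the compounds named here.

Measured in a functional assay on HOS-TE85 cells (Homo sapiens) for inhibition, read by CCK-8 assay, with a stated time of 72 h; a higher number here means a weaker inhibitor, a lower number a stronger inhibitor:
- Compound 1 `COc1ccccc1N1C(=O)CSC1c1cccc(C(=O)NCCCCn2cncn2)c1`: > 1000 nM (a limit, not a number)
- Compound 2 `COc1ccccc1N1C(=O)CSC1c1cccc(C(=O)NCCCCn2cccn2)c1`: 91.7 nM
- Compound 3 `COc1ccccc1N1C(=O)CSC1c1cccc(C(=O)NCCCCN2C(=O)C=CC2=O)c1`: > 1000 nM (a limit, not a number)

Compound 2, at 91.7 nM, is the only one of the three with an actual number, and it is the most potent of them in this assay. Compound 4 `O=C(NCCCCn1cccn1)c1cccc(C2SCC(=O)N2c2cccc(C3CC3)c2)c1` keeps the side chain of compound 2 and changes the group on the shared core: 3-cyclopropylphenyl in place of 2-methoxyphenyl on an amide-type nitrogen in a ring. Here 3-cyclopropylphenyl takes the place of 2-methoxyphenyl on an amide-type nitrogen in a ring.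

Among the compounds with values here, no measured step touches this position. The two large readable steps, an at least 10-fold lower number from compound 1 to compound 2 (1.03 log units; beyond the scatter) and an at least 10-fold higher number from compound 2 to compound 3 (1.03 log units; beyond the scatter), both change the group on the saturated chain carbon instead. They show that a single change can matter greatly in this series, but they give neither a size nor a direction for this one. No step beyond the scatter is therefore expected, though with much uncertainty. The expected change is a 1.3-fold higher number from compound 2 to compound 4 (0.12 log units; within the scatter). Compound 4 is estimated at 120 nM, with an expected range from 25 nM to 800 nM. The range stays wide in view of the limit of > 1000 nM in this assay, at which 2 of the 3 values shown sit.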

Compound 4, half-maximal inhibitory concentration: 299 nM
Beside the measured number, compound 4's estimate is 2.5-fold (0.40 log units) below it; low and high end bracket the measured number.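

Within the data shown here, putting 3-cyclopropylphenyl in place of 2-methoxyphenyl on the amide-type nitrogen in the ring gives a 3.3-fold higher number from compound 2 to compound 4 (0.51 log units; beyond the scatter) in this assay, so this position does influence the result, which the earlier compounds could not show. This step is modest, whereas the readable changes on the saturated chain carbon were large, and compound 4 still gives an actual number. Compound 1 and compound 3 each stand at a limit, not a number: the limit of > 1000 nM in this assay, at which 2 of the 4 values shown sit.

The change alters both the group on the phenyl ring and its place there, so the compounds shown cannot separate these two effects. A 3-methoxyphenyl or a 2-cyclopropylphenyl group on this nitrogen would tell them apart, and a plain phenyl would show what either group adds.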